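Hydroxy for azetidinyl on the shared core: efficacy notes

The source may hold more compounds than are shown below. What is called first, only, known or untested is meant among the compounds shown, and "the series" means these compounds.

Measured so far:
compound 1, `O=C(O)Cc1sc(C(c2ccc(F)cc2)c2ccc(F)cc2)nc1-c1ccnc(N2CCC2)c1`: 80%
compound 2, `O=C(O)Cc1sc(C(c2ccccc2)c2ccccc2)nc1-c1cccc(F)c1`: 80%

Both compounds were read in an in vitro functional assay on HEK285-7 cells for antagonist activity at prostaglandin D2 receptor 2 (Homo sapiens), read by BRET and beta-arrestin recruitment; a higher number here means a larger maximal response, a lower number a smaller maximal response. Compound 1 gives 80% in this assay, and compound 2 gives 80%. At the digits shown compound 1 stands level with compound 2, so nothing separates the two beyond the scatter of this assay; no step between them is recorded, and the two structures differ in more than one place, so only the two values themselves can be compared.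

Compound 3, `O=C(O)Cc1sc(C(c2ccc(F)cc2)c2ccc(F)cc2)nc1-c1ccnc(O)c1`, is still to be measured in this assay. It follows from compound 1 by one change: hydroxy in place of azetidin-1-yl on an aromatic carbon. Cut one bond further out, the change reads 2-(azetidin-1-yl)pyridin-4-yl to 2-hydroxypyridin-4-yl. No measured pair in the series carries this change, so its effect on the maximal response cannot be read off from the numbers shown.

The expected step of a number 8 percentage points lower from compound 1 to compound 3 (within the scatter) is a modest decrease, not clearly beyond the scatter. Compound 3 is estimated at 72% in this assay, with a range from 45% to 95%.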

Compound 3, largest response reached (reported as efficacy), in percent of the reference or control that the assay uses: 60%
The estimate for compound 3 lay 12 percentage points above the measured number; the range from low to high includes it.
By their numbers in this assay, from the lowest: compound 3; then compounds 1 and 2 (each within the scatter of the next).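

In this assay, among these compounds, hydroxy in place of azetidin-1-yl on the aromatic carbon next to the ring nitrogen gives a number 20 percentage points lower from compound 1 to compound 3 (beyond the scatter), the first single-place change that can be read. The maximal response at this position therefore depends on the group it carries, a point the two earlier compounds could not show because they differ in more than one place. The change removes a four-membered non-aromatic ring with 1 hetero atom and brings in 1 hydrogen-bond donor, but no measurement at hand bears on which of these differences, if either, lies behind the step.

The compounds shown leave open whether the lower response follows the loss of the azetidine ring or the arrival of the hydroxy group, a question that methoxy or dimethylamino at the same place would help to separate. A single step also leaves open whether a larger saturated amine such as pyrrolidin-1-yl would hold the response of compound 1 or move it in either direction.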